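Cyclobutyl for phenyl on the ring amide nitrogen

The compounds below may be only part of what the source reports. "The series", "measured", "known", "first", "only" and "open" are said of these compounds alone.

Measured so far in an assay on HEK293 cells for positive allosteric modulation of metabotropic glutamate receptor 2 (Rattus norvegicus), read by thallium flux; on this read-out higher numbers stand for larger maximal responses and lower numbers for smaller maximal responses:
compound 1 `O=C(O)c1cc(-c2cccc(COc3ccc4c(=O)n(C5CCCC5)oc4c3)c2)ccc1Cl` gives 64%
compound 2 `O=C(O)c1cc(-c2cccc(COc3ccc4c(c3)CN(c3ccccc3)C4=O)c2)ccc1Cl` gives 86.2%
compound 3 `CC(C)N1Cc2cc(OCc3cccc(-c4ccc(Cl)c(C(=O)O)c4)c3)ccc2C1=O` gives 88.1%

Compound 2 stands second highest of the three numbers. Its nearest neighbour is compound 3, reached by a number 1.9 percentage points higher from compound 2 to compound 3 (within the scatter). Furthest away is compound 1, whose value in this assay lies below that of compound 2 by a gap beyond the scatter; no single-point step is defined for that pair, so only the two values speak.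

Compound 4 `O=C(O)c1cc(-c2cccc(COc3ccc4c(c3)CN(C3CCC3)C4=O)c2)ccc1Cl` is not yet measured. It differs from compound 2 in one place: cyclobutyl in place of phenyl on an amide-type nitrogen in a ring

Within the data shown here, the one step that bears on this change is the one from compound 2 to compound 3, where isopropyl in place of phenyl on the amide-type nitrogen in a ring gave a number 1.9 percentage points higher from compound 2 to compound 3 (within the scatter), within the scatter. Cyclobutyl is likewise a small non-aromatic carbon ring entering at the same place, so no step beyond the scatter is expected in this assay. The expected step is a number 0.8 percentage points higher from compound 2 to compound 4 (within the scatter). For compound 4 the estimate is 87%, within a range of 74% to 99%.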

Compound 4, largest response reached (Emax), in percent of the reference or control that the assay uses: 90.3%
Compound 4: the middle estimate sits 3.3 percentage points below what was measured; the measured number falls inside the stated range.
By their numbers in this assay, from the lowest: compound 1; then compounds 2, 3 and 4 (each within the scatter of the next).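

In this assay, cyclobutyl on the amide-type nitrogen in a ring gives a number 4.1 percentage points higher from compound 2 to compound 4 (within the scatter), so a second non-aromatic carbon group joins isopropyl in showing no change from phenyl beyond the scatter. The ring and the open branched group also cannot be told apart, with a number 2.2 percentage points higher from compound 3 to compound 4 (within the scatter), and this position therefore holds the response across an aromatic ring, a four-membered ring and isopropyl. No measurement bearing on the reason for this flat response is available.

The compounds shown leave open how far this tolerance extends, in particular whether a longer chain ending in an amine or a carboxylic acid on this nitrogen would keep the response. They also leave open whether potency follows the same flat pattern as the largest response.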